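The source may report more compounds than this note shows. Statements on the series, on what has been measured and on what is new or still open speak of the compounds shown alone.

Compounds measured so far:
compound 1 `CCc1cc(C(C)=O)c(O)cc1OCCCC(C)(C)C(=O)O`, 43%;
compound 2 `CCc1cc(C(C)=O)c(O)cc1OCCCCCC(C)(C)c1nnn(C)n1`, 66%;
compound 3 `CCc1cc(C(C)=O)c(O)cc1OCCCCCCSC`, 14%.

In an assay on isolated protein for binding affinity to leukotriene B4 receptor 1 (Homo sapiens), tested at 1 uM (on this read-out higher numbers stand for more inhibition at the one concentration tested (going by the name of the read-out) and lower numbers for less inhibition), compound 3 stands lowest of the three, the nearest being compound 1 a number 29 percentage points lower from compound 1 to compound 3 (beyond the scatter) and the furthest compound 2 a number 52 percentage points lower from compound 2 to compound 3 (beyond the scatter). Compound 4 `CCc1cc(C(C)=O)c(O)cc1OCCCCCCS(C)(=O)=O` differs from compound 3 by methylsulfonyl in place of methylsulfanyl on a saturated chain carbon, six bonds along the chain from an oxygen on an aromatic ring. Within the data shown here, no measured step exchanges methylsulfanyl for methylsulfonyl, so the two known steps bear on it only indirectly: both show that the methylsulfanyl end of the chain in compound 3 sits well below the other chain ends tried. A small gain is therefore expected for compound 4 in this assay, a number 11 percentage points higher from compound 3 to compound 4 (beyond the scatter), though a step within the scatter would not surprise. Compound 4 is estimated at 25%, between 8% and 45%.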

Compound 4, a percentage reported as inhibition, at one concentration (the size of the read-out at that concentration, not a potency): 62%
The estimate for compound 4 lay 37 percentage points below the measured number, and the stated range ends below it.
By their numbers in this assay, from the lowest: compound 3; then compound 1; then compounds 4 and 2 (each within the scatter of the next).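

At the chain end, six bonds along the chain from an oxygen on an aromatic ring, methylsulfonyl in place of methylsulfanyl gives a number 48 percentage points higher from compound 3 to compound 4 (beyond the scatter) in this assay, so the end group alone, on an unchanged chain, can move this read-out substantially. The methylsulfonyl end, which has no ring, also gives a number 4 percentage points lower from compound 2 to compound 4 (within the scatter) against the tetrazole-bearing end and a number 19 percentage points higher from compound 1 to compound 4 (beyond the scatter) against the carboxylic acid end. Nothing available accounts for the size of these steps. Open, as far as these compounds go, is how a methylsulfinyl or sulfonamide end would read on the same chain, and how methylsulfonyl would read on a shorter chain.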